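The compounds below may be only part of what the source reports. "The series", "measured", "known", "first", "only" and "open" are said of these compounds alone.

Compound 1 `O=C(Nc1cccc(-n2cc(-c3ccncc3)c(-c3ccc(Cl)c(O)c3)n2)c1)Nc1cccc(C(F)(F)F)c1` joins the shared core through a urea to a 3-(trifluoromethyl)phenyl group. In a functional assay on M14 cells (Homo sapiens) for inhibition, read by sulforhodamine B assay, with a stated time of 48 h (a lower number here means a stronger inhibitor of growth, a higher number a weaker inhibitor of growth), compound 1 gives 10800 nM, the highest of the three numbers measured. Compound 2 `O=C(Nc1cccc(-n2cc(-c3ccncc3)c(-c3ccc(Cl)c(O)c3)n2)c1)Nc1ccc(Cl)c(Cl)c1` carries 3,4-dichlorophenyl in place of 3-(trifluoromethyl)phenyl on an amide-type nitrogen, and in this assay compound 2 gives 6970 nM. Compound 3 `COc1cc(-c2nn(-c3cccc(NC(=O)Nc4cccc(C(F)(F)F)c4)c3)cc2-c2ccncc2)ccc1Cl` has methyl in place of hydrogen on an oxygen on an aromatic ring, and in this assay compound 3 gives 1870 nM.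

Compound 4 `O=C(Nc1cccc(-n2cc(-c3ccncc3)c(-c3ccc(Cl)c(O)c3)n2)c1)Nc1cc(C(F)(F)F)cc(C(F)(F)F)c1` has not yet been measured. It differs from compound 1 in one place: trifluoromethyl in place of hydrogen on an aromatic carbon. Among the compounds with values here, two measured steps bear on this. The step on the same urea aryl group showed a 1.5-fold lower number from compound 1 to compound 2 (0.19 log units; within the scatter), and the step at the phenol oxygen, a different part of the molecule, showed a 5.8-fold lower number from compound 1 to compound 3 (0.76 log units; beyond the scatter). The change in compound 4 sits on the urea aryl group, and that group has so far been altered with no effect beyond the scatter, so the number in this assay is expected to move little in either direction: a 1.2-fold lower number from compound 1 to compound 4 (0.08 log units; within the scatter). Compound 4 is therefore estimated at 9000 nM in this assay, with a range from 3500 nM to 25000 nM.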

Compound 4, concentration for total growth inhibition: 1810 nM
For compound 4 the middle estimate is 5.0-fold (0.70 log units) above the measured one; measured number below the stated range.
By their numbers in this assay, from the lowest: compounds 4 and 3 (each within the scatter of the next); then compounds 2 and 1 (each within the scatter of the next).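

Trifluoromethyl in place of hydrogen on an aromatic carbon, meta to a large group and meta to a trifluoromethyl group, gives a 6.0-fold lower number from compound 1 to compound 4 (0.78 log units; beyond the scatter) in this assay, so the urea aryl group of compound 1 is a part of the molecule where a single change can carry the number beyond the scatter. Within the data shown here, the only earlier change on that group, 3,4-dichlorophenyl in place of 3-(trifluoromethyl)phenyl, gave a 1.5-fold lower number from compound 1 to compound 2 (0.19 log units; within the scatter), and that step alone had offered no sign of such a response. Nothing measured here accounts for the step to compound 4.

What a nitrile, an amine or a carboxylic acid would do on that same aromatic carbon stays open, so the compounds shown cannot tell whether the step belongs to trifluoromethyl in particular or to any group placed there. Also open is whether this change would give a step of similar size on compound 3, which has methyl on the phenol oxygen, since no compound shown carries both changes.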